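The source may report more compounds than this note shows. Statements on the series, on what has been measured and on what is new or still open speak of the compounds shown alone.

Working notes on the series. Compound 1 `CS(=O)(=O)Oc1c(C(=O)NCc2ccc(F)cc2)nc(Br)c2cccnc12` carries a (methylsulfonyl)oxy group on the core; in a functional assay on MDA-MB-435 cells (Homo sapiens) for cytotoxicity, read by MTT assay, with a stated time of 72 h (a higher number here means a weaker inhibitor, a lower number a stronger inhibitor), compound 1 reaches only the limit of the measurement, > 20000 nM, and gives no number. Compound 3 `CS(=O)(=O)NCCCN(c1nc(C(=O)NCc2ccc(F)cc2)c(O)c2ncccc12)S(C)(=O)=O` likewise sits at the limit in this assay, > 20000 nM. Of the three values in hand, two stand at this limit (the limit of > 20000 nM in this assay, at which 2 of the 3 values shown sit), so compound 1 is not placed on the scale at all. For the measured compounds named here, the one number comes from compound 2 `CN(C)c1ccc(CNC(=O)c2nc(Br)c3cccnc3c2N[C@H]2CC[C@H](N)CC2)cc1`, which in this assay gives 4000 nM.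

Compound 4 `NCCCCCCNc1c(C(=O)NCc2ccc(F)cc2)nc(Br)c2cccnc12` is not yet measured. It differs from compound 1 by a single substitution: (6-aminohexyl)amino in place of (methylsulfonyl)oxy on an aromatic carbon. Going by the values given here, no measured pair in this set shows the effect of a change at this position, so the size of the step has to be guessed. The expectation is a gain, from the limit down into the measurable range, with the step from compound 1 to compound 4 estimated at an at least 4.0-fold lower number from compound 1 to compound 4 (0.60 log units; beyond the scatter). Compound 4 is estimated at 5000 nM, with a range from 1500 nM to 20000 nM.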

Compound 4, half-maximal inhibitory concentration: 6000 nM
Compound 4: middle estimate off by 1.2-fold (0.08 log units), on the low side; measured number inside the range.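

In this assay, (6-aminohexyl)amino in place of (methylsulfonyl)oxy on this aromatic carbon, para to the bromo group, gives the first step readable at this position, an at least 3.3-fold lower number from compound 1 to compound 4 (0.52 log units; beyond the scatter), and moves the compound from the limit into the measurable range. From the compounds shown here alone, compound 1 stands at > 20000 nM, which is a limit and not a number, so this step is a bound and its full size stays unknown. The limit still holds a share of the series: the limit of > 20000 nM in this assay, at which 2 of the 4 values shown sit.

The compounds shown leave open whether the step follows the ring-bound amino link, the length of the chain or its terminal amine. A simple amine on this carbon, a shorter aminoalkyl chain, a longer one or a chain ending in a carboxylic acid would begin to separate these features.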